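This account rests on a few compounds, and the source may have more. Where it says the series, first, only, none or still open, it means among the compounds named here.

Measured in an ADME assay on NIH3T3 cells (Mus musculus) for inhibition, read by sulforhodamine B assay, with a stated time of 48 h; on this read-out higher numbers stand for weaker inhibition of growth and lower numbers for stronger inhibition of growth
compound 1 `COc1cc(C(=O)NNC(=O)c2ccc3[nH]c(-c4ccc([N+](=O)[O-])s4)nc3c2)cc(OC)c1OC` gives 31.3 ug/mL
compound 2 `O=CNNC(=O)c1ccc2[nH]c(-c3ccc([N+](=O)[O-])o3)nc2c1` gives 62.5 ug/mL
compound 3 `COc1ccc(C(=O)NNC(=O)c2ccc3[nH]c(-c4ccc([N+](=O)[O-])o4)nc3c2)cc1OC` gives 31.3 ug/mL

Compound 3 stands level with compound 1 at the digits reported, and compound 2 lies within the scatter of both. Still unmeasured is compound 4 `COc1cc(C(=O)NNC(=O)c2ccc3[nH]c(-c4ccc([N+](=O)[O-])o4)nc3c2)cc(OC)c1OC`, reached from compound 3 by methoxy in place of hydrogen on an aromatic carbon with methoxy in place of hydrogen on an aromatic carbon. For the measured compounds named here, only one measured step bears on this side of the molecule. That step is a 2.0-fold lower number from compound 2 to compound 3 (0.30 log units; within the scatter) and it adds a whole 3,4-dimethoxyphenyl rather than one methoxy, yet it stays within the scatter. Going by the values given here, no measured step isolates a single methoxy. Compound 4 shares its methoxy groups with compound 1 on a different core, and compound 1 gives 31.3 ug/mL in this assay with the same number as compound 3. For compound 4 the expected step is no change at the digits printed from compound 3 to compound 4 (within the scatter) and nothing beyond the scatter is expected. For compound 4 the estimated value is 31.3 ug/mL within an expected range from 15.6 ug/mL to 62.5 ug/mL.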

Compound 4, concentration for 50% growth inhibition: 31.3 ug/mL
Compound 4: the middle estimate sits on the measured number at the digits printed; the range from low to high includes it.
By their numbers in this assay, from the lowest: compounds 1, 3, 4 and 2 (each within the scatter of the next).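

In this assay a single added methoxy, on an aromatic carbon ortho to a methoxy group and meta to a large group, can now be read alone: the step is no change at the digits printed from compound 3 to compound 4 (within the scatter) and this position tolerates the third methoxy without a shift beyond the scatter. For the compounds shown here, the exchange of 5-nitrothiophen-2-yl for 5-nitrofuran-2-yl can also be read alone for the first time, as no change at the digits printed from compound 1 to compound 4 (within the scatter) on an otherwise identical molecule. Nothing available explains either result.

From the compounds shown here alone, whether a larger or charged group at this position, such as an amine or a carboxylic acid in place of the methoxy, would also leave the number within the scatter in this assay remains open. Also open, going by these compounds, is whether the two nitro-bearing groups stay level when a longer chain replaces the aromatic ring on the carbonyl carbon.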